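The source may hold more compounds than are shown below. What is called first, only, known or untested is meant among the compounds shown, and "the series" means these compounds.

In a functional assay on ACHN cells (Homo sapiens) for cytotoxicity, read by sulforhodamine B assay, with a stated time of 72 h (on this read-out higher numbers stand for weaker inhibition of growth and lower numbers for stronger inhibition of growth), compound 1 `O=C(Nc1ccccc1O)C1CCc2ccccc2N1C(=O)c1ccccc1Cl` gives 44200 nM and compound 2 `CCCC(=O)N1c2ccccc2CCC1C(=O)Nc1cc(C(F)(F)F)cc(C(F)(F)F)c1` gives 13900 nM. Compound 3 `CCCC(=O)N1c2ccccc2CCC1C(=O)Nc1ccccc1C(F)(F)F` reaches no number at all in this assay, only its limit of > 70000 nM; this is the boundary (the limit of > 70000 nM in this assay, at which 1 of the 3 values shown sits), so its growth inhibition is known only as weaker than that boundary. Compound 4 `CCCCCCCCC(=O)N1c2ccccc2CCC1C(=O)Nc1ccccc1C(F)(F)F` keeps the core and the amide of compound 3 and changes one place: pentyl in place of hydrogen on a saturated chain carbon, three bonds along the chain from a carbonyl carbon. Among the compounds with values here, no measured pair shows what lengthening this chain does, so the direction of the step cannot be read from the data. The step is estimated as an at least 1.4-fold lower number from compound 3 to compound 4 (0.14 log units; that floor lies within the scatter), with the expectation that compound 4 stays near the boundary or comes out somewhat stronger. Compound 4 is expected to give 50000 nM, ranging from 15000 nM to 150000 nM.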

Compound 4, concentration for 50% growth inhibition: 8330 nM
The estimate for compound 4 lay 6.0-fold (0.78 log units) above the measured number; measured number outside the range, below it.
By their numbers in this assay, from the lowest: compounds 4 and 2 (each within the scatter of the next); then compound 1. At a limit, above all of these: compound 3.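

In this assay, pentyl in place of hydrogen on a saturated chain carbon, three bonds along the chain from a carbonyl carbon, gives an at least 8.4-fold lower number from compound 3 to compound 4 (0.92 log units; beyond the scatter). Within the data shown here, this is the first sign that extending the chain at this place can strengthen growth inhibition. The true step may be larger, because compound 3 has only a limit and so the step is only a floor: the limit of > 70000 nM in this assay, at which 1 of the 4 values shown sits.

One step cannot show how the number changes with chain length. A shorter chain such as ethyl, a longer one such as heptyl, or an amine at the chain end would test whether it keeps falling or turns back.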